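From an Ester to an Amide on a Shared Core

The compounds below may be only part of what the source reports. "The series", "measured", "known", "first", "only" and "open" are said of these compounds alone.

Compound 1 `O=C(O)c1cccc2c(C(=O)c3ccccc3)cc(C(=O)c3ccc(C(Cl)(Cl)Cl)cc3)c-2c1`: 25.6% in an assay on cells for displacement of a labelled ligand from Orexin receptor type 2 (Homo sapiens), read by scintillation counting, with stated times of 10 min and 90 min, tested at 10 uM; on this read-out higher numbers stand for more inhibition at the one concentration tested (going by the name of the read-out) and lower numbers for less inhibition
Compound 2 `COC(=O)c1ccc2ccc(C=O)c-2cc1`: 37.2%
Compound 3 `COC(=O)c1ccc2c(C=O)cc(-c3ccccc3)c-2cc1`: 1.8%

Compound 3 gives the lowest of these three numbers in this assay: compound 1 stands higher than it and compound 2 higher still, both gaps beyond the usual scatter. Going by the values given here, only one measured pair differs in a single place, and that step, a number 35.4 percentage points lower from compound 2 to compound 3 (beyond the scatter), came with phenyl in place of hydrogen on an aromatic carbon. Compound 4 `NC(=O)c1ccc2c(C=O)cc(-c3ccccc3)c-2cc1` is compound 3 with one change: amino in place of methoxy on a carbonyl carbon. Among the compounds with values here, no measured pair touches the methoxy or the amino group, and the phenyl step says nothing about an exchange on the carbonyl carbon, so the data give no ground for a shift in either direction. The expected step is therefore a number 4.2 percentage points higher from compound 3 to compound 4 (within the scatter), within the scatter. Compound 4 is estimated at 6%, with a range from -8% to 25%.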

Compound 4, a percentage reported as inhibition, at one concentration (the size of the read-out at that concentration, not a potency): 16.7%
The estimate for compound 4 lay 10.7 percentage points below the measured number, and the stated range covers the measured number.
By their numbers in this assay, from the lowest: compound 3; then compounds 4 and 1 (each within the scatter of the next); then compound 2.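

Going by these compounds alone, exchanging methoxy for amino on a carbonyl carbon gives the first measured step at this place: in this assay, the change gives a number 14.9 percentage points higher from compound 3 to compound 4 (beyond the scatter). Within the data shown here, the earlier compounds showed only that the number responds to adding phenyl, whereas this pair shows that it also responds to a small exchange elsewhere on the shared core, one that swaps methoxycarbonyl for carbamoyl while the phenyl stays in place. No measurement shown here explains why the amino group gives the higher number.

On these data alone, it remains open whether a methylamino or dimethylamino group on the same carbonyl carbon would keep, extend or lose this step. Also open, as far as these compounds go, is whether the same exchange of methoxy for amino would give a similar step on compound 2, which has no phenyl.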